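This account rests on a few compounds, and the source may have more. Where it says the series, first, only, none or still open, it means among the compounds named here.

Compound 1, `CC(C)(NC(=O)Nc1ccc(F)c(C(F)(F)F)c1)C(=O)O`, carries a urea joined to a fluorinated, trifluoromethyl-bearing aromatic ring on one side and a 1-carboxy-1-methylethyl group on the other. In an ADME assay on microsomes from liver (Homo sapiens) for metabolic stability, using NADPH, with a stated time of 60 min (on this read-out lower numbers stand for slow clearance and higher numbers for fast clearance), compound 1 sits at a limit of the assay, < 7 uL/min. Compound 2, `O=C(O)CNC(=O)Nc1ccc(F)c(C(F)(F)F)c1`, keeps that shared core but places carboxymethyl on the amide-type nitrogen in place of 1-carboxy-1-methylethyl. In this assay compound 2 likewise returns only a limit, < 7 uL/min. The step that the two limits leave unreadable from compound 1 to compound 2 therefore cannot be read, because of the limit of < 7 uL/min in this assay, at which 2 of the 2 values shown sit, so the numbers shown give no direction for the change between these two groups. Compound 3, `O=C(Nc1ccc(F)c(C(F)(F)F)c1)NC1(C(=O)O)CC1`, is not yet measured; it differs from compound 2 in one place, (1-carboxycyclopropyl in place of carboxymethyl on an amide-type nitrogen). Among the compounds with values here, no measured step bears directly on this change. Both compounds sit at the same limit, so no step beyond the scatter is expected from a step that the limit leaves unreadable from compound 2 to compound 3. Compound 3 is therefore estimated to give 5 uL/min in this assay, with a range from 2 uL/min to 14 uL/min, and it is expected to sit at the limit again.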

Compound 3, intrinsic clearance in a liver preparation (reported as CLH), per the amount of preparation that the assay uses: < 7 uL/min
Compound 3 ended at the assay's limit; the forecaster's own chance of this, stated with the estimate: 65%; the middle value lies beyond the limit too.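

The result for compound 3 is again only a limit, so the steps among compound 1, compound 2 and compound 3 in this assay cannot be read: the limit of < 7 uL/min in this assay, at which 3 of the 3 values shown sit. The compounds shown leave open whether carboxymethyl, 1-carboxy-1-methylethyl and 1-carboxycyclopropyl on the amide-type nitrogen differ at all in this assay.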